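The compounds below may be only part of what the source reports. "The series", "measured", "known", "first", "only" and "open" are said of these compounds alone.

Of the compounds shown here, two have been measured so far. Compound 1 `NCCCc1c[nH]c2c(F)cccc12` was tested in an assay on isolated protein for inhibition of Myeloperoxidase (Homo sapiens), read by ELISA, with a stated time of 5 min (on this read-out lower numbers stand for stronger inhibition and higher numbers for weaker inhibition), and gives 26 nM. Compound 2 `NC(=O)CCCCc1c[nH]c2ccc(F)cc12` gives 43 nM in this assay. The two numbers lie within the usual scatter of each other, so no order between compound 1 and compound 2 can be read from them; compound 1 simply stands at one of two closely matched values.

The next compound, compound 3 `NC(=O)CCc1c[nH]c2c(F)cccc12`, has not yet been measured. It derives from compound 1 by a single change: carbamoyl in place of aminomethyl on a saturated chain carbon, two bonds along the chain from an aromatic carbon. For the measured compounds named here, no pair of measured compounds differs in exactly this way, so no step of this kind is known here. Compound 2 shows that a chain ending in carbamoyl can give a number in this range, while compound 1 carries the chain ending in the amine; the change in compound 3 is therefore expected to cost some potency, a step beyond the scatter toward a higher number, a 3.1-fold higher number from compound 1 to compound 3 (0.49 log units; beyond the scatter). On that basis compound 3 is estimated to give 80 nM in this assay, with a range from 25 nM to 300 nM.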

Compound 3, half-maximal inhibitory concentration: 64 nM
Beside the measured number, compound 3's estimate is 1.3-fold (0.10 log units) above it; low and high end bracket the measured number.
By their numbers in this assay, from the lowest: compounds 1, 2 and 3 (each within the scatter of the next, the first and the last beyond it).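

Replacing aminomethyl with carbamoyl on a saturated chain carbon, two bonds along the chain from an aromatic carbon, is now a measured change on the core of compound 1, and in this assay it gives a 2.5-fold higher number from compound 1 to compound 3 (0.39 log units; beyond the scatter) with everything else held the same. Compound 2 had shown only that a carbamoyl-ended chain could reach this range on a differently built compound, whereas the present pair shows that the amine of compound 1 can be exchanged at a modest cost, with compound 3 still at 64 nM in this assay after the exchange. No measurement available here explains why the carbamoyl group gives the higher number, so the step stands as an observation only.

The compounds shown leave open whether another end group on this chain, such as a carboxylic acid, a nitrile or a hydroxyl, would stay as close to compound 1 as carbamoyl does. They also leave open whether the same exchange would give a step of similar size on a longer chain, for which a matched pair of compounds would be needed.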